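Swapping the para group on compound 2 for a sulfamoyl

A few compounds are considered here, and "the series" means these few. Any claim that something is new, unique, unknown or untested is made for them only; others in the source may bear on it.

Compound 2 `CCOC(=O)c1ccc(NC(=O)N2CC2C#N)cc1` is the starting point. In a functional assay on WiDr cells (Homo sapiens) for inhibition (a higher number here means a weaker inhibitor, a lower number a stronger inhibitor), compound 2 gives 4200 nM, the lowest of the two numbers available. Its nearest neighbour is compound 1 `CCOC(=O)CNC(=O)N1CC1C#N`, which in this assay gives 33000 nM, a gap that lies beyond the usual scatter. Compound 3 `N#CC1CN1C(N)=O` reaches only a limit of the assay, giving > 280000 nM in this assay. The new compound 4 `N#CC1CN1C(=O)Nc1ccc(S(N)(=O)=O)cc1` keeps the shared core and differs from compound 2 in one place: sulfamoyl in place of ethoxycarbonyl on an aromatic carbon. Among the measured compounds shown here, no measured pair shows this swap, so its effect is uncertain; the step from compound 2 to compound 4 is expected to be small and towards a weaker inhibitor, a 1.7-fold higher number from compound 2 to compound 4 (0.22 log units; within the scatter). Compound 4 is therefore estimated at 7000 nM, within a range from 1500 nM to 30000 nM.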

Compound 4, half-maximal inhibitory concentration: > 38000 nM
Compound 4: only a limit was reported; the forecaster's own chance of this, stated with the estimate: 5%; middle value at least 5.4-fold (0.73 log units) from the limit.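

Sulfamoyl in place of ethoxycarbonyl on the aromatic carbon gives an at least 9.0-fold higher number from compound 2 to compound 4 (0.95 log units; beyond the scatter), so this position does not accept every small group equally in this assay. The step is a real loss of strength, and its full size is unknown, since compound 4 has only a limit and not a number: the limit of > 38000 nM in this assay, at which 1 of the 4 values shown sits.

Open, going by these compounds, is whether the ethyl part of the ester matters here, or the carbonyl. A carboxylic acid, an amine or a longer ester at this position would help separate these possibilities.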